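Ester replacements on the shared core: platelet inhibition notes

This account rests on a few compounds, and the source may have more. Where it says the series, first, only, none or still open, it means among the compounds named here.

compound 1 `CC(C)OC(=O)c1ccc(-c2nn(Cc3ccccc3)c3ccccc23)cc1` — > 10000 nM
compound 2 `CCCNC(=O)c1ccc(-c2nn(Cc3ccccc3)c3ccccc23)cc1` — > 10000 nM

Compound 2 stands only at a limit. In a functional assay on cells (Platelet, Homo sapiens) for inhibition (a higher number here means a weaker inhibitor, a lower number a stronger inhibitor), compound 2 gives > 10000 nM, which is a limit of the assay and not a number. Compound 1 stands the same way: in this assay compound 1 gives > 10000 nM, again a limit. Among the compounds with values here, the single measured step, a step that the two limits leave unreadable from compound 1 to compound 2, cannot be read in size or direction, since both of its ends sit at the limit of > 10000 nM in this assay, at which 2 of the 2 values shown sit.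

Compound 3 `CCOC(=O)/C=C/c1ccc(-c2nn(Cc3ccccc3)c3ccccc23)cc1` differs from compound 2 by 2-(ethoxycarbonyl)ethenyl in place of propylcarbamoyl on an aromatic carbon. No readable measured step bears on this change; the only one recorded is the unreadable one above, so nothing sets a direction or a size for this assay. The expected step, a step that the limit leaves unreadable from compound 2 to compound 3, is accordingly taken as none beyond the scatter, and a limit is again the likeliest outcome. Compound 3 is estimated at 15000 nM in this assay, within a range from 3000 nM to 60000 nM.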

Compound 3, half-maximal inhibitory concentration: > 10000 nM
Compound 3 ended at the assay's limit (the forecaster's own chance of this, stated with the estimate: 70%); the middle value is on the limit's open side.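

In this assay compound 3 gives > 10000 nM as a limit of the assay and not a number. The steps from compound 1 and compound 2 to compound 3 cannot be read: (the limit of > 10000 nM in this assay, at which 3 of the 3 values shown sit). The compounds shown leave open which change on the shared core, if any, gives a readable inhibition value.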